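This account rests on a few compounds, and the source may have more. Where it says the series, first, only, none or still open, it means among the compounds named here.

Among the measured compounds shown here, in a functional assay on A549 cells (Homo sapiens) for antiproliferative activity, read by MTT assay, with a stated time of 72 h (on this read-out lower numbers stand for stronger inhibition and higher numbers for weaker inhibition), compound 3 `Cc1nc(C)c(/C=C/C(=O)/C=C/c2ccccc2)nc1C` gives 12300 nM as the highest number of the three measured so far. Compound 1 `Cc1nc(C)c(/C=C/C(=O)/C=C/c2cccc(O)c2)nc1C` gives 4300 nM there and compound 2 `COc1cccc(/C=C/C(=O)/C=C/c2nc(C)c(C)nc2C)c1` gives 3300 nM there. Compound 4 `Cc1nc(C)c(/C=C/C(=O)/C=C/c2cccc([N+](=O)[O-])c2)nc1C` is compound 3 with one change: nitro in place of hydrogen on an aromatic carbon with nitro in place of hydrogen on an aromatic carbon, meta to a large group. Compound 1 and compound 2 carry hydroxy and methoxy on that ring. For the measured compounds named here, two measured steps bear on the change: a 2.9-fold higher number from compound 1 to compound 3 (0.46 log units; beyond the scatter) on losing hydroxy and a 3.7-fold higher number from compound 2 to compound 3 (0.57 log units; beyond the scatter) on losing methoxy. Both are modest and beyond the scatter. Going by the values given here, no nitro compound has been measured, so read in reverse they only suggest a modest drop. The expected step is a 2.2-fold lower number from compound 3 to compound 4 (0.35 log units; beyond the scatter) in this assay as a lower number. The estimate for compound 4 is 5500 nM with 2200 nM to 13000 nM as the expected range.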

Compound 4, half-maximal inhibitory concentration: 6700 nM
Beside the measured number, compound 4's estimate is 1.2-fold (0.09 log units) below it; the range from low to high includes it.
By their numbers in this assay, from the lowest: compounds 2, 1, 4 and 3 (each within the scatter of the next, the first and the last beyond it).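

In this assay nitro on this aromatic carbon gives a 1.8-fold lower number from compound 3 to compound 4 (0.26 log units; within the scatter) and so, unlike hydroxy and methoxy, does not move the number clear of the scatter from the unsubstituted compound 3. Swapping between groups at this place gives a 1.6-fold higher number from compound 1 to compound 4 (0.19 log units; within the scatter) which leaves nitro and hydroxy indistinguishable, and a 2.0-fold higher number from compound 2 to compound 4 (0.31 log units; beyond the scatter) which only modestly separates nitro from methoxy. Nothing measured here explains these differences. Still open, going by these compounds, is whether an amine or a carboxylic acid on this carbon would give a similar number, and whether nitro would give the same result on another carbon of the ring.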